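Carbamate series at the detection limit: ethyl to formyl

The source may hold more compounds than are shown below. What is called first, only, known or untested is meant among the compounds shown, and "the series" means these compounds.

Three carbamates have been tested in an assay for inhibition of zeta-carotene desaturase, chloroplastic/chromoplastic (Capsicum annuum), using a Dixon plot, with a stated time of 8 h (on this read-out higher numbers stand for weaker inhibition and lower numbers for stronger inhibition), so far, and none of them gave a number. Compound 1, `CCOC(=O)c1cccc(OCC(CC)OC(=O)NCc2ccccc2)c1`, reached only the limit > 100000 nM, which is a boundary of the assay rather than a measured value. Compound 2, `CCC(COc1cccc(C(F)(F)F)c1)OC(=O)NCc1ccccc1Cl`, likewise stopped at the limit > 100000 nM. Compound 3, `CCC(COc1cccc(Cl)c1)OC(=O)N(CC)Cc1ccccc1`, also sits at the limit > 100000 nM, so it stands exactly where every other value in this assay stands, as summed up by the limit of > 100000 nM in this assay, at which 3 of the 3 values shown sit. No pair of these compounds differs in a single place, so no measured step is available to lean on.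

Compound 4, `CCC(COc1cccc(Cl)c1)OC(=O)N(C=O)Cc1ccccc1`, differs from compound 3 by formyl in place of ethyl on an amide-type nitrogen. With every measured compound sitting at the limit, the step from compound 3 to compound 4 is expected to be a step that the limit leaves unreadable from compound 3 to compound 4, that is, no change beyond the scatter. Compound 4 is therefore estimated at 200000 nM in this assay, within a range from 50000 nM to 1000000 nM, and the most likely outcome is once more a limit rather than a number.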

Compound 4, half-maximal inhibitory concentration: > 100000 nM
Compound 4: no number, only a limit (the forecaster's own chance of this, stated with the estimate: 85%); the middle value does not contradict the limit.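

Compound 3 and compound 4 both end at a limit rather than a number, so formyl in place of ethyl cannot be read as a step: the limit of > 100000 nM in this assay, at which 4 of the 4 values shown sit. The compounds shown leave open whether any change to these carbamates would give a measurable value in this assay.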